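A few compounds are considered here, and "the series" means these few. Any claim that something is new, unique, unknown or untested is made for them only; others in the source may bear on it.

Among the compounds with values here, in a functional assay on MDA-MB-231 cells (Homo sapiens) for cytotoxicity, with a stated time of 3 days (a higher number here means a weaker inhibitor, a lower number a stronger inhibitor), compound 1 `c1csc(-c2cc(-c3ccoc3)cc(-c3cccs3)n2)c1` gives 23600 nM and compound 2 `Clc1ccc(-c2cc(-c3cccs3)nc(-c3cccs3)c2)o1` gives 54800 nM, the highest of the two numbers, compound 1 being the only neighbour. Within the data shown here, the one measured step, a 2.3-fold higher number from compound 1 to compound 2 (0.37 log units; beyond the scatter), concerns a change of the furan group and so does not bear directly on the move to compound 3 `Clc1ccc(-c2cc(-c3ccsc3)nc(-c3cccs3)c2)o1`, which is thiophen-3-yl in place of thiophen-2-yl on an aromatic carbon. Among the measured compounds shown here, no measured step informs this change; the expected step from compound 2 to compound 3 in this assay is therefore none beyond the scatter, a 1.1-fold lower number from compound 2 to compound 3 (0.04 log units; within the scatter). Compound 3 is estimated at 50000 nM, with a range from 18000 nM to 140000 nM.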

Compound 3, half-maximal inhibitory concentration: 26800 nM
Beside the measured number, compound 3's estimate is 1.9-fold (0.27 log units) above it; the range from low to high includes it.
By their numbers in this assay, from the lowest: compounds 1 and 3 (each within the scatter of the next); then compound 2.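

In this assay, thiophen-3-yl in place of thiophen-2-yl next to the ring nitrogen gives a 2.0-fold lower number from compound 2 to compound 3 (0.31 log units; beyond the scatter) with the same atoms present. This position therefore responds to the point of attachment of the thiophene alone, a change the earlier furan step did not address. Nothing measured accounts for this step.

From the compounds shown here alone, whether the step holds with furan-3-yl in place of the 5-chlorofuran-2-yl group remains open. So does the effect of an amine or a carboxylic acid at this position.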